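Oxadiazole to trifluoromethoxy: expected cytotoxicity of compound 3

This account rests on a few compounds, and the source may have more. Where it says the series, first, only, none or still open, it means among the compounds named here.

Compound 1 `CC(=O)Nc1cccc(-c2ccc(C(=O)N(Cc3cccc(OCCCCCC(=O)O)c3)C(C)C)cc2)c1` and compound 2 `Cc1nnc(-c2cccc(-c3ccc(C(=O)N(Cc4cccc(OCCCCCC(=O)O)c4)C(C)C)cc3)c2)o1` have the same core and differ at one aromatic carbon only. In an ADME assay on HepG2 cells (Homo sapiens) for cytotoxicity, read by CellTiter-Glo and resazurin assay, with a stated time of 72 h (a higher number here means that more compound is needed for the effect, a lower number that less compound is needed), compound 1 gives > 26000 nM, which is a limit of the assay and not a number. In this assay compound 2 gives > 26000 nM, again a limit. The step that the two limits leave unreadable from compound 1 to compound 2 therefore cannot be sized. Within the data shown here, compound 2 thus stands at the limit, as does the only other value shown, because of the limit of > 26000 nM in this assay, at which 2 of the 2 values shown sit. Compound 3 `CC(C)N(Cc1cccc(OCCCCCC(=O)O)c1)C(=O)c1ccc(-c2cccc(OC(F)(F)F)c2)cc1` is not yet measured, and it differs from compound 2 as follows: trifluoromethoxy in place of 5-methyl-1,3,4-oxadiazol-2-yl on an aromatic carbon. Among the measured compounds shown here, the single measured step bears on this change only loosely, since it also exchanges a group at the same aromatic carbon, and it stayed unreadable. The expected step is a step that the limit leaves unreadable from compound 2 to compound 3, nothing beyond the scatter. Compound 3 is expected to give 30000 nM in this assay, with a range from 13000 nM to 100000 nM, and most likely this will again be reported as a limit rather than a number.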

Compound 3, half-maximal effective concentration: > 26000 nM
Compound 3 ended at the assay's limit; the forecaster's own chance of this, stated with the estimate: 80%; the middle value lies beyond the limit too.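

Compound 3, like compound 1 and compound 2, sits at a limit of this assay and not at a number, so no step among these three compounds can be read: the limit of > 26000 nM in this assay, at which 3 of the 3 values shown sit.

The compounds shown leave open how much of each compound would be needed for the effect, and whether the group exchanged on the aromatic carbon changes that amount at all.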